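The source may hold more compounds than are shown below. What is called first, only, known or untested is meant among the compounds shown, and "the series" means these compounds.

Compound 1 `Cc1cccc(/C(N)=N/NC(=S)N2CCN(c3ccccn3)CC2)n1`: > 100000 nM
Compound 2 `N/C(=N\NC(=S)N1CCOCC1)c1ccccn1`: 4700 nM
Compound 3 `Cc1cccc(/C(N)=N/NC(=S)N2CCSCC2)n1`: > 100000 nM

These three compounds were tested in a functional assay on MCF7 cells (Homo sapiens) for cytotoxicity, read by MTT assay, with a stated time of 72 h; on this read-out higher numbers stand for weaker inhibition and lower numbers for stronger inhibition. The value for compound 1 is a limit of this assay rather than a measured number. The value for compound 3 is likewise a limit. Compound 1 therefore stands at the limit of > 100000 nM in this assay, at which 2 of the 3 values shown sit. Only compound 2 yields an actual number, and it differs from compound 1 in more than one place, so no single step can be read from that pair.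

Compound 4 `Cc1ccnc(/C(N)=N/NC(=S)N2CCN(c3ccccn3)CC2)c1` has not yet been tested. It differs from compound 1 by 4-methylpyridin-2-yl in place of 6-methylpyridin-2-yl on a carbon with a double bond to nitrogen; the two have the same atoms, joined differently. Going by the values given here, no measured step of this kind is available, so the expectation rests on compound 1 alone, which sits at the limit of > 100000 nM in this assay, at which 2 of the 3 values shown sit. The expected step from compound 1 to compound 4 is a number no higher from compound 1 to compound 4 (the limit leaves the size open), that is, none beyond the scatter. Compound 4 is accordingly estimated at 100000 nM, with a range from 20000 nM to 300000 nM, and most likely will again be reported only as a limit.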

Compound 4, half-maximal inhibitory concentration: 12300 nM
For compound 4 the middle estimate is 8.1-fold (0.91 log units) above the measured one; the measured number lies below the stated range.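

In this assay there is an at least 8.1-fold lower number from compound 1 to compound 4 (0.91 log units; beyond the scatter) when 4-methylpyridin-2-yl takes the place of 6-methylpyridin-2-yl on a carbon with a double bond to nitrogen. Going by these compounds alone, this is the first comparison here between compounds that differ in one place, and it shows that the read-out at this position changes with the placement of the methyl group alone, with no atom gained or lost. The true size of the step cannot be given because compound 1 is a limit rather than a number: the limit of > 100000 nM in this assay, at which 2 of the 4 values shown sit.

The compounds shown do not tell whether the same change would lower the number on the core of compound 3. They also leave open what an ethyl group, a methoxy group or a chlorine atom would do in place of the methyl group of compound 4.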